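A Methoxy Group on an Inactive Benzyl Series

This account rests on a few compounds, and the source may have more. Where it says the series, first, only, none or still open, it means among the compounds named here.

In an ADME assay on HeLa cells (Homo sapiens) for inhibition, read by MTT assay, with a stated time of 48 h (a lower number here means a stronger inhibitor, a higher number a weaker inhibitor), compound 1 `CCOC(=O)C(=O)CC(=O)/C=C/c1cn(Cc2ccccc2)c2ccccc12` gives > 40000 nM, which is a limit of the assay. Compound 2 `O=C(/C=C/c1cn(-c2ccc(Cl)cc2)c2ccccc12)CC(=O)C(=O)O` gives > 40000 nM, also a limit. Compound 3 `O=C(/C=C/c1cn(Cc2ccccc2)c2ccccc12)CC(=O)C(=O)O` gives > 40000 nM, again only a limit, so it has no number to build on. The set therefore rests at the limit of > 40000 nM in this assay, at which 3 of the 3 values shown sit. Compound 4 `COc1ccc(Cn2cc(/C=C/C(=O)CC(=O)C(=O)O)c3ccccc32)cc1` carries methoxy in place of hydrogen on an aromatic carbon, turning benzyl to 4-methoxybenzyl (methoxy in place of hydrogen on an aromatic carbon). For the measured compounds named here, two measured steps bear on this change, a step that the two limits leave unreadable from compound 1 to compound 3 and a step that the two limits leave unreadable from compound 2 to compound 3, and neither gives a size. No shift beyond the scatter is therefore expected in this assay, and the estimated step is a number no higher from compound 3 to compound 4 (the limit leaves the size open). Compound 4 is expected at 40000 nM, with an estimated range of 15000 nM to 80000 nM.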

Compound 4, half-maximal inhibitory concentration: > 40000 nM
Compound 4 ended at the assay's limit; the forecaster's own chance of this, stated with the estimate: 80%; the middle value sits exactly at the limit.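

Neither the step from compound 3 to compound 4 nor the step from compound 2 to compound 4 can be read, since all these values are only limits: the limit of > 40000 nM in this assay, at which 4 of the 4 values shown sit.

The compounds shown leave open how far any of them lies beyond that limit in this assay and whether the methoxy group changes potency at all.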